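A Second Swap of Fluoro for Methoxy

The compounds below may be only part of what the source reports. "The series", "measured", "known", "first", "only" and "open" are said of these compounds alone.

In a functional assay on PC-3 cells (Homo sapiens) for antiproliferative activity, read by MTT assay, with a stated time of 48 h (a higher number here means a weaker inhibitor, a lower number a stronger inhibitor), compound 1 `O=C(/C=C\Nc1ccc(F)cc1)c1cn(-c2ccccc2)nc1-c1ccc(F)cc1` gives 7900 nM. Compound 2 `O=C(/C=C\Nc1ccc(C(F)(F)F)cc1)c1cn(-c2ccccc2)nc1-c1ccc(F)cc1` reads > 50000 nM, which is a limit of the assay and not a number. Compound 3 `COc1ccc(N/C=C\C(=O)c2cn(-c3ccccc3)nc2-c2ccc(F)cc2)cc1` gives 4600 nM, a value within the usual scatter of compound 1, so these two stand level.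

Compound 4 `COc1ccc(N/C=C\C(=O)c2cn(-c3ccccc3)nc2-c2ccc(OC)cc2)cc1` differs from compound 3 in one place, where 4-fluorophenyl becomes 4-methoxyphenyl: methoxy in place of fluoro on an aromatic carbon. This is methoxy in place of fluoro on an aromatic carbon. Going by the values given here, the closest precedent is a 1.7-fold lower number from compound 1 to compound 3 (0.23 log units; within the scatter), the same kind of swap made elsewhere in the molecule. The larger steps, an at least 6.3-fold higher number from compound 1 to compound 2 (0.80 log units; beyond the scatter) and an at least 10-fold lower number from compound 2 to compound 3 (1.03 log units; beyond the scatter), both involve trifluoromethyl, which plays no part here. A single precedent at a different place is thin support, so the range stays wide. The expected change is a 1.0-fold lower number from compound 3 to compound 4 (0.01 log units; within the scatter), with no shift beyond the scatter anticipated. For compound 4 the estimate is 4500 nM, with an expected range from 1500 nM to 15000 nM.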

Compound 4, half-maximal inhibitory concentration: 13400 nM
Compound 4: middle estimate off by 3.0-fold (0.47 log units), on the low side; the measured number falls inside the stated range.
By their numbers in this assay, from the lowest: compounds 3, 1 and 4 (each within the scatter of the next, the first and the last beyond it). At a limit, above all of these: compound 2.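

Moving from 4-fluorophenyl to 4-methoxyphenyl in this assay gives a 2.9-fold higher number from compound 3 to compound 4 (0.46 log units; beyond the scatter), so at this position, para to a large group, the swap makes the compound a weaker inhibitor by more than the usual scatter. The same exchange of fluoro for methoxy elsewhere in the molecule gave a 1.7-fold lower number from compound 1 to compound 3 (0.23 log units; within the scatter), so its effect cannot be carried from one place to the other. Nothing given here bears on why this step occurs.

Going by these compounds, the result at this position rests on a single pair, measured with methoxy already present at the other place, so it remains open whether the step would hold with fluoro there instead. On these data alone, it also remains open how a hydroxy group, an amine or a chloro group would read at this position, and so whether losing fluoro or gaining methoxy drives the step.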